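This account rests on a few compounds, and the source may have more. Where it says the series, first, only, none or still open, it means among the compounds named here.

Compound 1 `O=C(Nc1nc2nc(-c3ccccc3)cc(O)n2n1)c1ccccc1` reads > 250000 nM in an ADME assay on MDCK cells (Canis lupus familiaris) for cytotoxicity, read by MTT assay, with a stated time of 48 h (on this read-out higher numbers stand for lower toxicity in this test and lower numbers for higher toxicity in this test), and this value is a limit of the assay. For the measured compounds named here, compound 2 `CCCOc1ccc(C(=O)Nc2nc3nc(-c4ccccc4)cc(C)n3n2)cc1` gives 247000 nM in this assay and so holds the only actual number so far. Compound 3 `COc1ccc(C(=O)Nc2nc3nc(-c4ccccc4)cc(C)n3n2)cc1` differs from compound 2 by a single change, hydrogen in place of ethyl on a saturated chain carbon bound to an oxygen on an aromatic ring with hydrogen in place of ethyl on a saturated chain carbon bound to an oxygen on an aromatic ring, turning propoxy into methoxy. Going by the values given here, the data hold no step that shows what this change does in this assay so the expected step of a 1.0-fold lower number from compound 2 to compound 3 (0.01 log units; within the scatter) stays within the scatter, with no firm direction. For compound 3 the estimated value is 240000 nM with an expected range from 120000 nM to 450000 nM in this test.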

Compound 3, half-maximal cytotoxic concentration: > 250000 nM
Compound 3 ended at the assay's limit; the forecaster's own chance of this, stated with the estimate: 45%; middle value at least 1.0-fold (0.01 log units) away from the limit.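

Swapping propoxy for methoxy gives the only step read so far at this place, on a saturated chain carbon bound to an oxygen on an aromatic ring, in this assay: an at least 1.0-fold higher number from compound 2 to compound 3 (0.00 log units; that floor lies within the scatter). So the shorter chain shows no firm shift in either direction. How far the step actually runs cannot be read, because compound 3 stands at a limit of the assay: the limit of > 250000 nM in this assay, at which 2 of the 3 values shown sit.

Going by these compounds, whether a longer chain, an amine or a carboxylic acid in place of propoxy would give a clearly lower number stays open. The compounds shown tell nothing about such groups.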